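The source may report more compounds than this note shows. Statements on the series, on what has been measured and on what is new or still open speak of the compounds shown alone.

Compound 1, `CCCCc1cnc(C(CCCO)Cc2ccc(-c3ccccc3C(=O)O)cc2)[nH]1`, gives 1900 nM in an in vitro functional assay on cells for agonist activity at Bombesin receptor subtype-3 (Homo sapiens), read by luminescence and calcium flux; a higher number here means that more compound is needed for the effect, a lower number that less compound is needed.
Compound 2, `O=C(O)c1ccccc1-c1ccc(CCc2ncc(CC3CCCCC3)[nH]2)cc1`, gives 41 nM in this assay.
Compound 3, `CCCCc1cnc(/C=C/c2ccc(-c3ccccc3C(=O)O)cc2)[nH]1`, gives 4380 nM in this assay.

Of the three measured compounds, compound 2 stands lowest in this assay, so it needs the least compound for the effect. Its nearest neighbour is compound 1, whose number is higher by a margin beyond the scatter, and compound 3 lies further still. Both compound 1 and compound 3 carry a shorter chain where compound 2 carries its cyclohexylmethyl group, and both differ from compound 2 in the linker as well, so no single change separates any pair.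

Compound 4, `O=C(O)c1ccccc1-c1ccc(CCc2ncc(Cc3ccccc3Cl)[nH]2)cc1`, has not yet been measured. It differs from compound 2 in one place: 2-chlorophenyl in place of cyclohexyl on a saturated chain carbon bound to an aromatic carbon. The group that leaves and the group that enters are of similar size and count, but one is saturated and the other aromatic with a chlorine. Among the compounds with values here, no measured pair shows this exchange, so nothing here tells how large such a step tends to be. The expectation is a step of modest size from compound 2 to compound 4 of a 2.2-fold higher number from compound 2 to compound 4 (0.34 log units; beyond the scatter), most likely toward a somewhat higher number. Compound 4 is therefore estimated at 90 nM, with a range from 20 nM to 400 nM.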

Compound 4, half-maximal effective concentration: 292 nM
Compound 4: the middle estimate sits 3.2-fold (0.51 log units) below what was measured, and the stated range covers the measured number.
By their numbers in this assay, from the lowest: compound 2; then compound 4; then compound 1; then compound 3.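

In this assay, within the data shown here, the exchange of cyclohexyl for 2-chlorophenyl on a saturated chain carbon bound to an aromatic carbon gives the first step that can be read at one place, a 7.1-fold higher number from compound 2 to compound 4 (0.85 log units; beyond the scatter). This position therefore does not treat these two six-membered rings alike, even though the entering group adds only the chlorine to the heavy-atom count and neither group has hydrogen-bond donors or acceptors. No measurement shown here explains why the number rises.

Two things change at once in this exchange, the ring turns aromatic and a chlorine appears, and the compounds shown do not separate them. A plain phenyl at this place, or a ring bearing an amine, would be needed to tell how each part contributes.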